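The compounds below may be only part of what the source reports. "The series", "measured", "known", "first", "only" and "open" are said of these compounds alone.

In an assay on HEK293 cells for inhibition of Voltage-dependent T-type calcium channel subunit alpha-1G (Homo sapiens), read by patch clamp (a lower number here means a stronger inhibitor, a higher number a weaker inhibitor), compound 1 `CCCc1nc(-c2ccccc2)c(CNCCCN2CCN(c3ccccc3F)CC2)o1` gives 16100 nM, compound 2 `CCCc1nc(-c2ccccc2)c(CNCCCN2CCN(c3cccc(C)c3C)CC2)o1` gives 1780 nM, and compound 3 `CCCc1nc(-c2ccccc2)c(CNCCN2CCN(c3ccc(Cl)cc3)CC2)o1` gives 2820 nM. Going by the values given here, the one single-change step so far is a 9.0-fold lower number from compound 1 to compound 2 (0.96 log units; beyond the scatter). Compound 3 has the second highest of the three numbers; its value sits within the scatter of that of compound 2, while compound 1 lies beyond the scatter above it. Compound 4 `CCCc1nc(-c2ccccc2)c(CNCCN2CCN(c3cccc(Cl)c3)CC2)o1` differs from compound 3 by 3-chlorophenyl in place of 4-chlorophenyl on an amine nitrogen in a ring. Among the compounds with values here, no measured step moves a chlorine on this ring; the step from compound 1 to compound 2 changed the whole group on the same nitrogen, so it offers only a loose guide. A step within the scatter, a 1.1-fold lower number from compound 3 to compound 4 (0.05 log units; within the scatter), is therefore expected, and compound 4 is estimated at 2500 nM with a range from 900 nM to 7000 nM.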

Compound 4, half-maximal inhibitory concentration: 1450 nM
Compound 4: the middle estimate sits 1.7-fold (0.24 log units) above what was measured, and the stated range covers the measured number.
By their numbers in this assay, from the lowest: compounds 4, 2 and 3 (each within the scatter of the next); then compound 1.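

Moving the chlorine, with 3-chlorophenyl in place of 4-chlorophenyl on the amine nitrogen in a ring, gives a 1.9-fold lower number from compound 3 to compound 4 (0.29 log units; within the scatter) in this assay. Going by these compounds alone, this is the first direct look at where the chlorine sits on this ring, and with the same atoms joined differently, the two compounds cannot be told apart beyond the usual scatter of repeats. Nothing available accounts for the small shift. Still open, as far as these compounds go, is whether a methoxy group or a nitrile in place of the chlorine would move the number beyond that scatter.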